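Working notes: ethyl for hydrogen in compound 2

A few compounds are considered here, and "the series" means these few. Any claim that something is new, unique, unknown or untested is made for them only; others in the source may bear on it.

The series is followed in an assay on RBL-1 cells for inhibition of Polyunsaturated fatty acid 5-lipoxygenase (Rattus norvegicus); on this read-out lower numbers stand for stronger inhibition and higher numbers for weaker inhibition. Of the compounds shown here, two carry numbers so far. Compound 1 `CC(c1ccc(OCc2ccccc2)cc1)N(O)C(=O)c1ccccc1` gives 690 nM in this assay. Compound 2 `CCCCOc1ccc(CN(O)C(C)=O)cc1` gives 1100 nM in this assay, the higher of the two numbers, yet compound 1 and compound 2 lie within the scatter of each other, so no order between them can be read. Within the data shown here, the two also differ in several places at once, so no single step can be drawn from them.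

Compound 3 `CCCCOc1ccc(C(CC)N(O)C(C)=O)cc1` has not yet been measured. It differs from compound 2 in one place only: ethyl in place of hydrogen on a saturated chain carbon bound to an amide-type nitrogen and an aromatic carbon. Among the measured compounds shown here, no measured pair shows a change of this kind, so the size of the step rests on expectation alone. Compound 1, which gives 690 nM, differs from compound 2 in more than this one place and cannot serve as a guide. The step of a 1.7-fold lower number from compound 2 to compound 3 (0.23 log units; within the scatter) is expected to be small and toward a lower number, probably not beyond the scatter. Compound 3 is estimated at 650 nM in this assay, with a range from 200 nM to 2000 nM.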

Compound 3, half-maximal inhibitory concentration: 740 nM
Estimate against measurement, compound 3: 1.1-fold (0.06 log units) below; low and high end bracket the measured number.
By their numbers in this assay, from the lowest: compounds 1, 3 and 2 (each within the scatter of the next).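

The series now holds its first single-place step: in this assay, ethyl in place of hydrogen on a saturated chain carbon bound to an amide-type nitrogen and an aromatic carbon gives a 1.5-fold lower number from compound 2 to compound 3 (0.17 log units; within the scatter) as the measured size of this change. This place therefore accepts ethyl, a group of 2 heavy atoms with no ring, and neither a gain nor a loss can be read from the change, as compound 3 stays within the scatter of compound 2. Nothing measured on these compounds bears on why the step has this size.

From the compounds shown here alone, one group at this place is a single point, so it remains open whether methyl, a longer chain such as butyl, a phenyl ring or an amine on the same carbon would also stay within the scatter of compound 2. Also open, going by these compounds, is whether ethyl in place of hydrogen would give a step of similar size on the core of compound 1, which differs from compound 3 in more than one place and so offers no comparison.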